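Swapping a methyl for a chlorine on the indazole

The source may report more compounds than this note shows. Statements on the series, on what has been measured and on what is new or still open speak of the compounds shown alone.

Compounds measured so far:
compound 1, `CCCC/C(=C(/c1ccc(/C=C/C(=O)O)cc1)c1ccc2[nH]ncc2c1)c1ccccc1`, 10 nM
compound 2, `CC/C(=C(/c1ccc(/C=C/C(=O)O)cc1)c1cc2cn[nH]c2cc1C)c1ccccc1`, 468 nM

In a functional assay on MCF7 cells (Homo sapiens) for cytotoxicity, read by CellTiter-Glo, with a stated time of 5 days (a lower number here means a stronger inhibitor, a higher number a weaker inhibitor), compound 2 gives the highest of the two numbers shown; compound 1 gives the lower one, and the gap between them lies beyond the usual scatter. Compound 1 differs from compound 2 in two places at once, the alkyl chain and the substitution of the indazole, so no single-change step is shown and the two values can only be set side by side.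

Compound 3, `CC/C(=C(/c1ccc(/C=C/C(=O)O)cc1)c1ccc2[nH]ncc2c1Cl)c1ccccc1`, keeps the ethyl chain of compound 2 and changes only the indazole part: 4-chloro-1H-indazol-5-yl in place of 6-methyl-1H-indazol-5-yl on a double-bonded chain carbon bound to an aromatic carbon and a double-bonded chain carbon. Among the measured compounds shown here, with no measured step of this kind on record, the size and direction of the change can only be guessed from the fact that compound 1, which carries an unsubstituted indazole, sits far below compound 2.

The estimate for compound 3 is 80 nM, with a range from 15 nM to 400 nM, and the expected step is a 5.9-fold lower number from compound 2 to compound 3 (0.77 log units; beyond the scatter).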

Compound 3, half-maximal inhibitory concentration: 1.6 nM
Estimate against measurement, compound 3: 50-fold (1.70 log units) above, and the stated range ends above it.
By their numbers in this assay, from the lowest: compound 3; then compound 1; then compound 2.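

In this assay, putting 4-chloro-1H-indazol-5-yl in place of 6-methyl-1H-indazol-5-yl gives a 290-fold lower number from compound 2 to compound 3 (2.47 log units; beyond the scatter), while the ethyl chain and the rest of the core stay the same. Compound 1 and compound 2 differ in two places at once, so they could not tie any part of their gap to the indazole alone, whereas this step shows that the indazole part by itself can shift the number by a large amount. Nothing measured here explains why the step is so large.

The step also changes two things together, the atom or group on the indazole and the number in its name, so the compounds shown cannot tell how much of the shift belongs to chlorine in place of methyl and how much to the new location. A 4-methyl-1H-indazol-5-yl or 6-chloro-1H-indazol-5-yl compound with the ethyl chain would separate the two, and a 4-fluoro-1H-indazol-5-yl compound would show whether a halogen other than chlorine behaves in the same way.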